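From Methoxy to Hydroxy on a Shared Core

A few compounds are considered here, and "the series" means these few. Any claim that something is new, unique, unknown or untested is made for them only; others in the source may bear on it.

In a functional assay on J774.A1 cells (Mus musculus) for inhibition, read by Griess assay, with stated times of 1 h and 24 h (a lower number here means a stronger inhibitor, a higher number a weaker inhibitor), compound 1 `CC(C)CCOc1ccccc1C1CC(=O)c2ccccc2O1` gives 42600 nM and compound 2 `COc1ccccc1C1CC(=O)c2ccccc2O1` gives 44500 nM. Within the data shown here, compound 2 holds the higher of only two numbers, but the gap lies within the scatter, so the two compounds stand level. The next compound, compound 3 `O=C1CC(c2ccccc2O)Oc2ccccc21`, keeps the shared core and carries hydrogen in place of methyl on an oxygen on an aromatic ring, or methoxy to hydroxy: hydrogen in place of methyl on an oxygen on an aromatic ring. Among the measured compounds shown here, only one measured step bears on this change: a 1.0-fold higher number from compound 1 to compound 2 (0.02 log units; within the scatter). It altered the group on the same oxygen, replacing isobutyl with hydrogen on a saturated chain carbon bound to that oxygen, and this assay did not separate the two compounds. For the measured compounds named here, no compound with a hydroxy group has been measured, so this single step is limited guidance, and the range must stay wide. No step beyond the scatter is expected in either direction. The estimated step is a 1.1-fold lower number from compound 2 to compound 3 (0.05 log units; within the scatter). Compound 3 is expected at 40000 nM, with an estimated range of 16000 nM to 90000 nM.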

Compound 3, half-maximal inhibitory concentration: 71300 nM
For compound 3 the middle estimate is 1.8-fold (0.25 log units) below the measured one, within the range that was stated.
By their numbers in this assay, from the lowest: compounds 1, 2 and 3 (each within the scatter of the next).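

In this assay, the oxygen on an aromatic ring now carries hydrogen as well as methyl and isopentyl, and the change from methoxy to hydroxy reads as a 1.6-fold higher number from compound 2 to compound 3 (0.20 log units; within the scatter) for this position. Taking away the whole chain, hydrogen in place of isopentyl on the same oxygen, reads as a 1.7-fold higher number from compound 1 to compound 3 (0.22 log units; within the scatter) and also stays inside the usual spread of repeated measurements, so the hydroxy compound stands level with both ethers and this assay does not separate the three groups tried at this place. No accompanying measurement bears on this result, and the numbers alone offer no account of why these groups read alike.

What the three compounds leave open is whether any group on this oxygen can move the number beyond the scatter, for instance a carboxylic acid or an amine carried at the end of a chain, or a chain much longer than isopentyl. They also leave open whether changes elsewhere on the shared core would read differently, as all three compounds differ only on this one oxygen.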